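The source may hold more compounds than are shown below. What is called first, only, known or untested is meant among the compounds shown, and "the series" means these compounds.

Measured compounds:
compound 1, `O=C(O)COc1cccc(CCC/C=N/OC(c2ccccc2)c2ccccc2)c1` — 3900 nM
compound 2, `CCCCCC(O)/C=C/CCC1CCCc2c(OCC(=O)O)cccc21` — 9600 nM
compound 3, `O=C(O)COc1cccc2c1CCC(C/C=C/C(O)Cc1ccccc1)C2` — 4900 nM

All three values come from an assay for displacement of a labelled ligand from prostacyclin receptor (Homo sapiens); a lower number here means a stronger inhibitor, a higher number a weaker inhibitor. Compound 3 gives 4900 nM and stands second highest of the three numbers; the nearest is compound 1 with 3900 nM, a gap within the scatter, and the furthest is compound 2 with 9600 nM, also within the scatter. Within the data shown here, on these numbers the three compounds cannot be separated, and no step between compounds that differ in one place is available.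

The next compound is compound 4, `CCCCCC(O)/C=C/CC1CCc2c(cccc2OCC(=O)O)C1`, not yet measured in this assay. It differs from compound 3 by butyl in place of phenyl on a saturated chain carbon, two bonds along the chain from a double-bonded chain carbon and an oxygen on a saturated carbon. Among the measured compounds shown here, compound 2 carries a hydroxyhexyl chain on a different core and gives 9600 nM, while compound 3 with the hydroxy-phenylethyl chain gives 4900 nM; those two values lie within the scatter of each other, and there is no matched pair to show the size of the phenyl-to-butyl change on its own. The expectation is therefore a step from compound 3 to compound 4 of no more than the scatter, if anything slightly toward a higher number, as a 1.2-fold higher number from compound 3 to compound 4 (0.09 log units; within the scatter). Compound 4 is estimated at 6000 nM, with a range from 2500 nM to 15000 nM.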

Compound 4, half-maximal inhibitory concentration: 7800 nM
Beside the measured number, compound 4's estimate is 1.3-fold (0.11 log units) below it; low and high end bracket the measured number.
By their numbers in this assay, from the lowest: compounds 1, 3, 4 and 2 (each within the scatter of the next, the first and the last beyond it).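

In this assay the series now has its first pair that differs in one place, and it gives a small step (a 1.6-fold higher number from compound 3 to compound 4 (0.20 log units; within the scatter)) for butyl in place of phenyl on a saturated chain carbon, two bonds along the chain from a double-bonded chain carbon and an oxygen on a saturated carbon. Read one bond further out, the same difference is benzyl to pentyl, so on this core a six-membered aromatic ring of carbon only at the chain end can give way to an open chain end with no step beyond the scatter. Nothing measured here offers an explanation for this result.

The compounds shown leave open whether a cyclohexyl group or a longer chain at this carbon would also stay within the scatter of compound 3 and compound 4, or whether either would give a step beyond it. Also open, as far as these compounds go, is whether a step beyond the scatter would appear with an amine or an ether oxygen placed in this part of the chain, since only carbon groups have been compared at this position.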